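The source may hold more compounds than are shown below. What is called first, only, known or untested is meant among the compounds shown, and "the series" means these compounds.

Working notes on the series, read in a physicochemical assay for solubility, using the shake flask method, in simulated intestinal fluid, measured as kinetic solubility, with a stated time of 2 h, at 25 degrees C, at pH 6.5; a lower number here means a less soluble compound, a higher number a more soluble compound. Compound 1 `Cc1noc(-c2nc(C)c3c(c2N)C(=O)N(Cc2ccc(-n4cccn4)cc2)C3=O)n1` gives only a limit, < 5000 nM, and no number. Compound 2 `Cc1noc(-c2nc(C)c3c(c2N)C(=O)N(Cc2ccccc2Cl)C3=O)n1` also gives only a limit, < 5000 nM. Within the data shown here, compound 2 therefore has no numerical position, and the two measured compounds provide no step that could be sized. The next compound is compound 3 `Cc1noc(-c2nc(C)c3c(c2N)C(=O)N(Cc2ccc(OC(F)F)cc2)C3=O)n1`, which has 4-(difluoromethoxy)phenyl in place of 2-chlorophenyl on a saturated chain carbon bound to an amide-type nitrogen in a ring. No change beyond the scatter is expected in this assay, in either direction, and another limit reading is the likeliest outcome. The expected change is a step that the limit leaves unreadable from compound 2 to compound 3. The estimate for compound 3 is 3500 nM, with an expected range of 1200 nM to 9000 nM.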

Compound 3, solubility: < 5000 nM
Compound 3 ended at the assay's limit (the forecaster's own chance of this, stated with the estimate: 80%); the middle value is on the limit's open side.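

No step can be read from compound 1, compound 2 or compound 3 in this assay, since each gives only a limit: the limit of < 5000 nM in this assay, at which 3 of the 3 values shown sit.

The compounds shown leave open the actual solubility of all three and whether their differing groups change it at all.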